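Aryl substituent ortho to methylsulfonyl: chloro to methyl

The source may report more compounds than this note shows. Statements on the series, on what has been measured and on what is new or still open speak of the compounds shown alone.

In a functional assay on CHO cells for agonist activity at Glucose-dependent insulinotropic receptor (Homo sapiens), read by a luciferase reporter and cAMP accumulation, with a stated time of 2 h (on this read-out lower numbers stand for an effect already at smaller amounts and higher numbers for an effect only at larger amounts of compound), compound 3 `CC(C)(C)OC(=O)N1CCC(CCOC(=O)N2CCc3c2ccc(S(C)(=O)=O)c3Cl)CC1` gives 530 nM, the highest number among the three measured compounds. Compound 1 `CC(C)(C)OC(=O)N1CCC(CCOC(=O)N2CCc3cc(S(C)(=O)=O)ccc32)CC1` gives 68 nM and compound 2 `CC(C)(C)OC(=O)N1CCC(CCOC(=O)N2CCc3c2ccc(S(C)(=O)=O)c3F)CC1` gives 25 nM in this assay. The measured steps at this position are a 2.7-fold lower number from compound 1 to compound 2 (0.43 log units; beyond the scatter), a 7.8-fold higher number from compound 1 to compound 3 (0.89 log units; beyond the scatter) and a 21-fold higher number from compound 2 to compound 3 (1.33 log units; beyond the scatter). Compound 4 `Cc1c(S(C)(=O)=O)ccc2c1CCN2C(=O)OCCC1CCN(C(=O)OC(C)(C)C)CC1` differs from compound 3 by methyl in place of chloro on an aromatic carbon. Going by the values given here, no measured step exchanges chloro for methyl, so the only guidance is that hydrogen and fluoro at this carbon give clearly lower numbers than chloro, while a group of similar size to chloro is untested. The step from compound 3 to compound 4 in this assay is therefore expected to be small, a somewhat lower number at most, and may not exceed the scatter: a 1.8-fold lower number from compound 3 to compound 4 (0.25 log units; within the scatter). For compound 4 the expected value in this assay is 300 nM, with a range from 80 nM to 1200 nM.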

Compound 4, half-maximal effective concentration: 770 nM
Compound 4: the middle estimate sits 2.6-fold (0.41 log units) below what was measured; low and high end bracket the measured number.
By their numbers in this assay, from the lowest: compound 2; then compound 1; then compounds 3 and 4 (each within the scatter of the next).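

In this assay, methyl in place of chloro on this aromatic carbon, ortho to a methylsulfonyl group, does not separate the two groups (a 1.5-fold higher number from compound 3 to compound 4 (0.16 log units; within the scatter)). The high numbers at this carbon are therefore not peculiar to chloro: methyl stands well apart from fluoro (a 31-fold higher number from compound 2 to compound 4 (1.49 log units; beyond the scatter)) and from hydrogen (an 11-fold higher number from compound 1 to compound 4 (1.05 log units; beyond the scatter)), so the four compounds fall into two sets, hydrogen and fluoro on one side and chloro and methyl on the other. No measurement shown here accounts for this split.

On these data alone, whether methoxy, a nitrile or an amine on this carbon would fall with hydrogen and fluoro or with chloro and methyl remains open. Also open, as far as these compounds go, is whether ethyl or trifluoromethyl would follow methyl.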